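The source may report more compounds than this note shows. Statements on the series, on what has been measured and on what is new or still open speak of the compounds shown alone.

Measured compounds:
Compound 1 `c1ccc(CNCCCCN(C[C@H]2Cc3ccccc3CN2)[C@H]2CCCc3cccnc32)cc1` gives 20.1 nM in a functional assay on cells for antagonist activity at C-X-C chemokine receptor type 4 (Homo sapiens), read by fluorescence and calcium flux, with stated times of 25 min and 90 s; on this read-out higher numbers stand for weaker inhibition and lower numbers for stronger inhibition.
Compound 2 `CC1(C)CCC(NCc2ccc(CN(C[C@H]3Cc4ccccc4CN3)[C@H]3CCCc4cccnc43)cc2)CC1` gives 661 nM.
Compound 3 `c1ccc(CNCc2ccc(CN(C[C@H]3Cc4ccccc4CN3)[C@H]3CCCc4cccnc43)cc2)nc1` gives 286 nM.

Compound 1 stands lowest of the three numbers; compound 3 is nearest and compound 2 is furthest, and both gaps lie beyond the scatter. Among the measured compounds shown here, the one step between compounds that differ in a single place is a 2.3-fold lower number from compound 2 to compound 3 (0.36 log units; beyond the scatter); it concerns a swap of the group on an amine nitrogen, not the chain itself, so it bears only loosely on what follows.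

Compound 4 `C(=C/CN(C[C@H]1Cc2ccccc2CN1)[C@H]1CCCc2cccnc21)\CNC1CCOCC1` has not been measured. It differs from compound 1 by 3-((oxan-4-yl)amino)prop-1-en-1-yl in place of 3-(benzylamino)propyl on a saturated chain carbon bound to an amine nitrogen. For the measured compounds named here, no measured pair shows a change of this kind, and compounds 2 and 3 show that altering the link and the terminal group on the amine can move the number well beyond the scatter. The step is therefore expected to be a 3.0-fold higher number from compound 1 to compound 4 (0.47 log units; beyond the scatter), toward a weaker inhibition. Compound 4 is estimated at 60 nM, with a range from 15 nM to 300 nM.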

Compound 4, half-maximal inhibitory concentration: 15.5 nM
Compound 4: the middle estimate sits 3.9-fold (0.59 log units) above what was measured, within the range that was stated.
By their numbers in this assay, from the lowest: compounds 4 and 1 (each within the scatter of the next); then compound 3; then compound 2.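

In this assay, replacing 3-(benzylamino)propyl with 3-((oxan-4-yl)amino)prop-1-en-1-yl on a saturated chain carbon bound to an amine nitrogen gives a 1.3-fold lower number from compound 1 to compound 4 (0.11 log units; within the scatter), so the two compounds cannot be told apart on this read-out. This position therefore accepts a non-aromatic ring with one hetero atom in place of the aromatic ring of carbon only, together with a double bond in the chain, without a shift beyond the scatter. Nothing measured here accounts for this result, and no explanation can be offered for it.

On these data alone, the ring and the double bond change together, so the share of each stays open. As far as these compounds go, whether a carboxylic acid or a longer chain in place of the oxan-4-yl group would hold the number in this assay at this level also stays open.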